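The source may hold more compounds than are shown below. What is called first, only, known or untested is meant among the compounds shown, and "the series" means these compounds.

Every compound here shares the core of compound 1 `Cc1nc(NC(C)C)nc(N[C@@H]2C[C@H](CO)[C@@H](O)[C@H]2O)c1-c1nc2ccccc2s1`, which in an ADME assay on cells (Homo sapiens) for cytotoxicity, read by polymerase chain reaction, with a stated time of 3 days (on this read-out higher numbers stand for lower toxicity in this test and lower numbers for higher toxicity in this test), gives 13000 nM. Compound 2 `Cc1nc(NCCNC(=O)NC(C)(C)C)nc(N[C@@H]2C[C@H](CO)[C@@H](O)[C@H]2O)c1-c1nc2ccccc2s1` carries a 2-(((tert-butyl)carbamoyl)amino)ethyl in place of the isopropyl on a nitrogen on an aromatic ring. In this assay compound 2 reaches only a limit of the assay and no fixed number, > 25000 nM. The step of an at least 1.9-fold higher number from compound 1 to compound 2 (0.28 log units; that floor lies within the scatter) rests on that limit (the limit of > 25000 nM in this assay, at which 1 of the 2 values shown sits), so compound 2 stands at the upper edge of the numbers shown rather than at a settled point. Compound 3 `Cc1nc(NCCNS(C)(=O)=O)nc(N[C@@H]2C[C@H](CO)[C@@H](O)[C@H]2O)c1-c1nc2ccccc2s1` differs from compound 2 in one place: methylsulfonyl in place of (tert-butyl)carbamoyl on an amine nitrogen. Among the measured compounds shown here, only the step from compound 1 to compound 2 bears on this change, and its floor lies within the scatter. For compound 3 no shift beyond the scatter is therefore expected in this assay, a number no higher from compound 2 to compound 3 (the limit leaves the size open). Compound 3 is expected to give about 25000 nM, with a range from 10000 nM to 60000 nM.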

Compound 3, half-maximal cytotoxic concentration: > 25000 nM
Compound 3 ended at the assay's limit (the forecaster's own chance of this, stated with the estimate: 60%); the middle value sits exactly at the limit.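

In this assay compound 3 also gives only a limit of the assay, > 25000 nM. This shows that the amine nitrogen can carry methylsulfonyl as well as (tert-butyl)carbamoyl and the read-out still reaches the limit, while 2-(methanesulfonamido)ethyl in place of isopropyl gives an at least 1.9-fold higher number from compound 1 to compound 3 (0.28 log units; that floor lies within the scatter). The step between the two groups on the amine nitrogen cannot be read, because both values are limits: the limit of > 25000 nM in this assay, at which 2 of the 3 values shown sit.

Going by these compounds, how far compound 2 and compound 3 lie past the limit stays open, as does whether either truly differs from compound 1 by more than the scatter. On these data alone, it also stays open whether an acetyl or a carboxylic acid in place of methylsulfonyl on the amine nitrogen, or a longer chain, would still reach this limit.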